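The source may hold more compounds than are shown below. What is called first, only, known or untested is meant among the compounds shown, and "the series" means these compounds.

Measured so far:
- Compound 1 `COc1ncnc2c1c(-c1ccccc1)cn2[C@@H]1O[C@H](CO)[C@@H](O)[C@H]1O`: > 20000 nM
- Compound 2 `CNc1ncnc2c1c(-c1ccccc1)cn2[C@@H]1O[C@H](CO)[C@@H](O)[C@H]1O`: > 20000 nM

Both entries come from a functional assay on HeLa S3 cells (Homo sapiens) for antiproliferative activity, read by XTT assay, with a stated time of 72 h (a higher number here means a weaker inhibitor, a lower number a stronger inhibitor), and neither is a number: each is a limit of the assay. Compound 1 therefore stands at the limit of > 20000 nM in this assay, at which 2 of the 2 values shown sit, with no exact value to start from.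

Compound 3 `COc1nc(N)nc2c1c(-c1ccccc1)cn2[C@@H]1O[C@H](CO)[C@@H](O)[C@H]1O` keeps the methoxy group of compound 1 and differs in one place: amino in place of hydrogen on an aromatic carbon, between two ring nitrogen atoms.

Among the measured compounds shown here, only one measured step exists, a step that the two limits leave unreadable from compound 1 to compound 2. It replaces the methoxy group and leaves this carbon untouched, so it offers no size to carry over.

The expectation therefore rests on compound 1 and its limit of > 20000 nM. No step beyond the usual scatter is expected in this assay, and another limit is the likeliest report. The expected change is a number no higher from compound 1 to compound 3 (the limit leaves the size open). For compound 3 the estimate is 20000 nM, with an expected range of 8000 nM to 40000 nM.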

Compound 3, half-maximal inhibitory concentration: > 20000 nM
Compound 3: only a limit was reported (the forecaster's own chance of this, stated with the estimate: 85%); the middle value sits exactly at the limit.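

Compound 3 gives a limit and not a number, and compound 1 also gives only a limit, so the step between these two compounds cannot be read: the limit of > 20000 nM in this assay, at which 3 of the 3 values shown sit.

Whether the amino group changes activity at all stays open, since the compounds shown give no exact value in this assay.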